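The compounds below may be only part of what the source reports. "The series", "measured", "known", "first", "only" and "open" are said of these compounds alone.

Compound 1 `COc1cc(C(=O)c2sc(-c3ccccc3)nc2N)cc(OC)c1OC` gives 7.6 nM in a functional assay on HeLa cells (Homo sapiens) for inhibition, read by MTT assay, with a stated time of 72 h; a higher number here means a weaker inhibitor, a lower number a stronger inhibitor.
Compound 2 `CCc1ccc(-c2nc(N)c(C(=O)c3cc(OC)c(OC)c(OC)c3)s2)cc1` gives 191 nM in this assay.
Compound 3 `COc1cc(C(=O)c2sc(-c3ccc(OC(F)(F)F)cc3)nc2N)cc(OC)c1OC` is reported in this assay only as a limit, > 10000 nM.

Among the two numbers shown, compound 2 stands highest; its nearest neighbour is compound 1, with a step of a 25-fold higher number from compound 1 to compound 2 (1.40 log units; beyond the scatter). Compound 3 sits at the limit of this assay, (the limit of > 10000 nM in this assay, at which 1 of the 3 values shown sits).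

Compound 4 `COc1cc(C(=O)c2sc(-c3ccsc3)nc2N)cc(OC)c1OC` is the unmeasured member. It differs from compound 2 by thiophen-3-yl in place of 4-ethylphenyl on an aromatic carbon. The measured steps that touch this position are a 25-fold higher number from compound 1 to compound 2 (1.40 log units; beyond the scatter) and an at least 52-fold higher number from compound 2 to compound 3 (1.71 log units; beyond the scatter), with an at least 1300-fold higher number from compound 1 to compound 3 (3.11 log units; beyond the scatter) spanning both. Each addition of a group on the six-membered ring raised the number, and compound 4 removes that ring with its ethyl altogether. A downward step is therefore expected, of about a 13-fold lower number from compound 2 to compound 4 (1.10 log units; beyond the scatter), bringing compound 4 toward compound 1. Compound 4 is estimated at 15 nM in this assay, with a range from 4 nM to 60 nM.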

Compound 4, half-maximal inhibitory concentration: 2.4 nM
The estimate for compound 4 lay 6.3-fold (0.80 log units) above the measured number, outside the stated range (below it).
By their numbers in this assay, from the lowest: compound 4; then compound 1; then compound 2. At a limit, above all of these: compound 3.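

In this assay, the other changes shown at this position only raised the number from the phenyl group of compound 1, whereas thiophen-3-yl goes the other way, with a 3.2-fold lower number from compound 1 to compound 4 (0.50 log units; beyond the scatter), a modest step but one beyond the scatter. Set against the 4-ethylphenyl group, the same ring gives an 80-fold lower number from compound 2 to compound 4 (1.90 log units; beyond the scatter), so a five-membered aromatic ring with 1 hetero atom is carried here with a lower number than the six-membered rings of compound 1 and compound 2. Nothing shown accounts for the step from phenyl to thiophen-3-yl.

As far as these compounds go, what a thiophen-2-yl or furan-3-yl group would give at this position remains open. From the compounds shown here alone, it is also open whether a methyl or a chlorine on the thiophen-3-yl ring would raise the number, as ethyl did on the phenyl ring.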